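Swapping the Amide Arm for a Nitro Group

This account rests on a few compounds, and the source may have more. Where it says the series, first, only, none or still open, it means among the compounds named here.

Compound 3 `O=C(CCl)Nc1ccc(-c2nc3cc(C(F)(F)F)ccc3[nH]2)cc1` gives 22000 nM in an ADME assay on BHK cells (Mesocricetus auratus) for cytotoxicity, read by MTT assay, with a stated time of 96 h (on this read-out higher numbers stand for lower toxicity in this test and lower numbers for higher toxicity in this test), the highest of the two numbers shown. Its nearest neighbour is compound 1 `O=C(CN1CCCCC1)Nc1ccc(-c2nc3cc(C(F)(F)F)ccc3[nH]2)cc1`, which gives 12000 nM, and the step of a 1.8-fold higher number from compound 1 to compound 3 (0.26 log units; within the scatter) lies within the scatter. Compound 2 `COc1ccc(-c2nc3cc(Cl)c(Cl)cc3[nH]2)c(N)c1` reaches only the limit of > 100000 nM in this assay. Compound 4 `O=[N+]([O-])c1ccc(-c2nc3cc(C(F)(F)F)ccc3[nH]2)cc1` differs from compound 3 by nitro in place of ((chloromethyl)carbonyl)amino on an aromatic carbon. Going by the values given here, no measured step concerns this change; the one measured step sits on the saturated chain carbon and is itself within the scatter, so it gives no direction. The step of a 1.1-fold lower number from compound 3 to compound 4 (0.04 log units; within the scatter) is therefore expected to stay within the scatter. Compound 4 is estimated at 20000 nM, with a range from 5000 nM to 80000 nM.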

Compound 4, half-maximal cytotoxic concentration: 18000 nM
Compound 4: the middle estimate sits 1.1-fold (0.05 log units) above what was measured, within the range that was stated.
By their numbers in this assay, from the lowest: compounds 1, 4 and 3 (each within the scatter of the next). At a limit, above all of these: compound 2.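

In this assay, nitro in place of ((chloromethyl)carbonyl)amino on the aromatic carbon gives a 1.2-fold lower number from compound 3 to compound 4 (0.09 log units; within the scatter) and so sets no direction at this position. The earlier step concerned only the saturated chain carbon, whereas this one shows that the whole amide arm and nitro cannot be told apart in this test. No measurement shown explains this result.

On these data alone, whether an amine or a carboxylic acid on this aromatic carbon would move the number beyond the scatter remains open. So does the effect of a longer chain on the amide arm.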